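The compounds below may be only part of what the source reports. "The series", "measured", "known", "first", "only" and "open" are said of these compounds alone.

Compound 1 `O=C(Nc1cccc(-n2cc(-c3ccncc3)c(-c3cc(O)cc(Cl)c3)n2)c1)Nc1ccc(Cl)c(Cl)c1` gives 95%
Compound 2 `COc1cc(Cl)cc(-c2nn(-c3cccc(NC(=O)Nc4ccc(Cl)c(C(F)(F)F)c4)c3)cc2-c2ccncc2)c1` gives 57%

In a functional assay on ACHN cells (Homo sapiens) for inhibition, read by sulforhodamine B assay, with a stated time of 48 h, tested at 0.1 uM (a higher number here means a weaker effect of the compound at the concentration tested, a lower number a stronger effect), compound 2 stands lowest of the two numbers shown; its nearest neighbour, compound 1, lies higher by a difference beyond the usual scatter. Compound 3 `COc1cc(Cl)cc(-c2nn(-c3cccc(NC(=O)Nc4ccc(Cl)c(Cl)c4)c3)cc2-c2ccncc2)c1` has not yet been measured. It differs from compound 2 by chloro in place of trifluoromethyl on an aromatic carbon. Among the compounds with values here, no measured pair shows this change on its own, so the size of the step is uncertain; a modest rise, near the edge of the scatter, is expected. Compound 3 is estimated at 68%, with a range from 40% to 92%. The expected step of a number 11 percentage points higher from compound 2 to compound 3 (beyond the scatter) points upward.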

Compound 3, a percentage reported as activity, at one concentration (the size of the read-out at that concentration, not a potency): 96%
Compound 3: the middle estimate sits 28 percentage points below what was measured; the measured number lies above the stated range.
By their numbers in this assay, from the lowest: compound 2; then compounds 1 and 3 (each within the scatter of the next).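

In this assay, the trifluoromethyl on this aromatic carbon proves decisive at the concentration tested: chloro in its place gives a number 39 percentage points higher from compound 2 to compound 3 (beyond the scatter). Within the data shown here, with chloro present, methyl in place of hydrogen on an oxygen on an aromatic ring gives a number 1 percentage points higher from compound 1 to compound 3 (within the scatter), so that change shows no effect in this pair. Nothing available explains the large step. From the compounds shown here alone, it remains open whether a nitrile or an amine on this carbon would behave like trifluoromethyl or like chloro. Going by these compounds, the effect of the hydrogen on that oxygen alongside trifluoromethyl also remains open.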